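The source may hold more compounds than are shown below. What is called first, only, known or untested is meant among the compounds shown, and "the series" means these compounds.

In a functional assay on MIA PaCa-2 cells (Homo sapiens), read by MTT assay, with a stated time of 72 h (on this read-out lower numbers stand for stronger inhibition and higher numbers for weaker inhibition), the measured compounds stand as follows:
Compound 1, `COc1cc(NC(C)CCCNC(=O)NC2CCCCC2)c2ncccc2c1`, gives 38000 nM.
Compound 2, `CCN(CC)C(=O)NCCCC(C)Nc1cc(OC)cc2cccnc12`, gives only the assay limit > 100000 nM.
Compound 3, `COc1cc(NC(C)CCCNC(=O)n2nnc3ccccc32)c2ncccc2c1`, gives 84000 nM.

Among the two numbers, compound 3 stands highest; its nearest neighbour is compound 1, and the step between them is a 2.2-fold higher number from compound 1 to compound 3 (0.34 log units; beyond the scatter). The remaining value, that of compound 2, is a limit rather than a number (the limit of > 100000 nM in this assay, at which 1 of the 3 values shown sits).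

Compound 4, `COc1cc(NC(C)CCCNC(=O)NCC2CCCCC2)c2ncccc2c1`, differs from compound 3 in one place: a group of 8 heavy atoms (7 carbon, 1 nitrogen; one six-membered non-aromatic ring of carbon only) in place of a group of 9 heavy atoms (6 carbon, 3 nitrogen; one five-membered aromatic ring with 3 hetero atoms, one six-membered aromatic ring of carbon only), on a carbonyl carbon. The measured steps that bear on this change all sit on the same carbonyl carbon. The step of a 2.2-fold higher number from compound 1 to compound 3 (0.34 log units; beyond the scatter) shows what the bicyclic group costs against cyclohexylamino; the change to compound 4 reverses that exchange and adds a methylene to the ring-bearing group. Among the measured compounds shown here, the step of an at least 1.1-fold lower number from compound 2 to compound 3 (0.07 log units; that floor lies within the scatter) and the step of an at least 2.6-fold higher number from compound 1 to compound 2 (0.42 log units; beyond the scatter) add only that the open-chain diethylamino group leaves the value of compound 2 as a limit. On this basis compound 4 is expected to return to the region of compound 1. The step is estimated as a 2.1-fold lower number from compound 3 to compound 4 (0.32 log units; beyond the scatter), a modest lowering. Compound 4 is therefore estimated at 40000 nM, with a range from 15000 nM to 100000 nM.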

Compound 4, half-maximal inhibitory concentration: 60000 nM
Compound 4: the middle estimate sits 1.5-fold (0.18 log units) below what was measured; the range from low to high includes it.
By their numbers in this assay, from the lowest: compounds 1, 4 and 3 (each within the scatter of the next, the first and the last beyond it). At a limit, above all of these: compound 2.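

In this assay, cyclohexylmethyl in place of cyclohexyl on the amide-type nitrogen gives a 1.6-fold higher number from compound 1 to compound 4 (0.20 log units; within the scatter), and (cyclohexylmethyl)amino in place of the bicyclic group on the carbonyl carbon gives a 1.4-fold lower number from compound 3 to compound 4 (0.15 log units; within the scatter); both steps lie within the scatter. Compounds 1 and 3 stood apart beyond the scatter, but compound 4 lies within the scatter of each, so this change does not separate it from either and adds no clear gain or loss at this position. The step of an at least 1.6-fold lower number from compound 2 to compound 4 (0.22 log units; that floor lies within the scatter) rests only on a floor, and the value of compound 2 stays a limit: the limit of > 100000 nM in this assay, at which 1 of the 4 values shown sits.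

The compounds shown leave open whether a longer chain such as cyclohexylethyl, or a benzyl or phenyl group on the same amide-type nitrogen, would move the number beyond the scatter from that of compound 1. They also leave open whether an amine or a carboxylic acid on the cyclohexyl ring would shift the value, and they give no reason for the differences seen here.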